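The source may hold more compounds than are shown below. What is called first, only, known or untested is meant among the compounds shown, and "the series" means these compounds.

For the measured compounds named here, in a functional assay on CWR22R cells (Homo sapiens) for antiproliferative activity, read by CCK-8 assay, with a stated time of 6 days (on this read-out higher numbers stand for weaker inhibition and lower numbers for stronger inhibition), compound 2 `CCN(c1ccc(C#N)c(Cl)c1)c1cc(-c2ccc(F)nc2)ccc1C` gives 16500 nM, the only actual number so far. Compound 1 `CCN(c1ccc(C#N)c(Cl)c1)c1cc(-c2ccco2)ccc1C` reports only a limit, > 30000 nM. Going by the values given here, the single measured step, an at least 1.8-fold lower number from compound 1 to compound 2 (0.25 log units; that floor lies within the scatter), is therefore a floor that lies within the scatter, and it rests on (the limit of > 30000 nM in this assay, at which 1 of the 2 values shown sits).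

Compound 3 `CCN(c1ccc(C#N)c(Cl)c1)c1cc(-c2cn[nH]c2)ccc1C` has not yet been measured. Its change from the previous compound is 1H-pyrazol-4-yl in place of 6-fluoropyridin-3-yl on an aromatic carbon, meta to a large group and para to a methyl group. Among the compounds with values here, the one measured step bears directly on this, since it also exchanges the ring at this place. That exchange, which led to compound 2 at 16500 nM, shows no change beyond the scatter, so no step beyond the scatter is expected in this assay. The estimated change is a 1.4-fold lower number from compound 2 to compound 3 (0.14 log units; within the scatter), and its direction is not firm. For compound 3 the estimate is 12000 nM, with an expected range from 3000 nM to 30000 nM.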

Compound 3, half-maximal inhibitory concentration: > 30000 nM
Compound 3 was reported as a limit; the forecaster's own chance of this, stated with the estimate: 25%; middle value at least 2.5-fold (0.39 log units) away from the limit.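

The exchange of 6-fluoropyridin-3-yl for 1H-pyrazol-4-yl, which brings in a five-membered aromatic ring with a hydrogen-bond donor, gives an at least 1.8-fold higher number from compound 2 to compound 3 (0.25 log units; that floor lies within the scatter) in this assay, so this second change of ring at the position also yields only a floor and no step beyond the scatter. What is new is that a second five-membered ring, after the furan-2-yl of compound 1, gives no actual number, leaving the six-membered ring of compound 2 as the only one of the three with a measured value. That contrast is no more than a hint, and it rests on limits rather than numbers: the limit of > 30000 nM in this assay, at which 2 of the 3 values shown sit.

Compound 1 and compound 3 both stand as limits, and the step between them cannot be read. As far as these compounds go, it remains open whether a plain phenyl ring, a pyridin-3-yl ring without the fluorine, or a morpholine at this place would move the number beyond the scatter from that of compound 2.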